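This account rests on a few compounds, and the source may have more. Where it says the series, first, only, none or still open, it means among the compounds named here.

Compound 1 `C=CC(=O)Nc1ccc(Cn2nc(-c3ccc(Oc4ccccc4)cc3)cc2C(=O)O)cc1`: > 60000 nM
Compound 2 `O=C(CCl)Nc1ccc(Cn2nc(-c3ccc(Oc4ccccc4)cc3)cc2CO)cc1`: 400 nM

Both compounds were tested in a functional assay on Z-138 cells (Homo sapiens) for inhibition, read by luminescence and CellTiter-Glo, with a stated time of 72 h; a higher number here means a weaker inhibitor, a lower number a stronger inhibitor. Compound 1 gives only a limit, > 60000 nM, and no number; this is the limit of > 60000 nM in this assay, at which 1 of the 2 values shown sits. Within the data shown here, compound 2 gives 400 nM, the only actual number in this assay, so it stands alone, and no comparison between measured compounds can be drawn from these two entries.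

Compound 3 `C/C=C/C(=O)Nc1ccc(Cn2nc(-c3ccc(Oc4ccccc4)cc3)cc2CO)cc1` has not been measured. It differs from compound 2 in one place: prop-1-en-1-yl in place of chloromethyl on a carbonyl carbon. Put simply, a prop-1-en-1-yl group replaces chloromethyl on a carbonyl carbon whose other neighbour is an amide-type nitrogen. Among the measured compounds shown here, no step between measured compounds exists to set the size of such a change, so the expectation rests on the structural change alone. Compound 3 is expected to be a weaker inhibitor, with a step of a 6.3-fold higher number from compound 2 to compound 3 (0.80 log units; beyond the scatter) that reaches beyond the usual scatter of repeated measurements. Compound 3 is therefore estimated at 2500 nM, within a range from 500 nM to 12000 nM.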

Compound 3, half-maximal inhibitory concentration: 54500 nM
For compound 3 the middle estimate is 22-fold (1.34 log units) below the measured one; the measured number lies above the stated range.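

This position is sensitive to what it carries. On the carbonyl carbon whose other neighbour is an amide-type nitrogen, putting prop-1-en-1-yl in place of chloromethyl brings a 140-fold higher number from compound 2 to compound 3 (2.13 log units; beyond the scatter) in this assay, so a swap confined to this small group, with the rest of the structure unchanged, takes most of the inhibition away. Among these compounds, this is also the first single-place step in the set, and it gives the earlier entries a scale they lacked: one change here is enough to move the number far beyond the scatter. The limit shown belongs to compound 1, which differs from compound 3 in more than one place and so adds no further step here: the limit of > 60000 nM in this assay, at which 1 of the 3 values shown sits.

One step cannot tell whether the loss comes from removing chloromethyl or from bringing in prop-1-en-1-yl, and no cause for it can be read from these values. Open too, going by these compounds, is how a plain methyl group, a bromomethyl group or a longer chain ending in an amine would read on that same carbonyl carbon.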